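A Methoxy Step Repeated on a Weaker Core

The source may hold more compounds than are shown below. What is called first, only, known or untested is meant among the compounds shown, and "the series" means these compounds.

Compound 1 `COc1ccc(CS(=O)(=O)/C=C/c2ccc(F)cc2)cc1` and compound 2 `COc1ccc(CS(=O)(=O)/C=C/c2ccc(F)cc2OC)cc1` differ in one place: methoxy in place of hydrogen on an aromatic carbon. In a functional assay on BT-20 cells (Homo sapiens) for antiproliferative activity, read by trypan blue exclusion (on this read-out lower numbers stand for stronger inhibition and higher numbers for weaker inhibition), compound 1 gives 1500 nM, while compound 2 gives 15000 nM, so that a 10-fold higher number from compound 1 to compound 2 (1.00 log units; beyond the scatter). Compound 3 `COc1ccc(CS(=O)(=O)/C=C/c2cc(OC)ccc2OC)cc1` carries a different core; the difference between the two cores is not broken down here. In this assay compound 3 gives only a limit, > 20000 nM. For the measured compounds named here, one of the three values so far sits at the limit of > 20000 nM in this assay, at which 1 of the 3 values shown sits. Compound 4 `COc1ccc(CS(=O)(=O)/C=C/c2cc(OC)c(OC)cc2OC)cc1` has not been measured; it differs from compound 3 by methoxy in place of hydrogen on an aromatic carbon. This is the same kind of change as from compound 1 to compound 2, though the surroundings differ: there the entering methoxy was ortho to a large group and meta to a fluoro group, here it is ortho to a methoxy group, meta to a methoxy group and para to a large group. The expectation rests on compound 3 standing at the limit > 20000 nM. It also rests on the earlier step, a 10-fold higher number from compound 1 to compound 2 (1.00 log units; beyond the scatter). Compound 4 is expected to show a step that the limit leaves unreadable from compound 3 to compound 4. Compound 4 is therefore estimated at 40000 nM.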

Compound 4, half-maximal inhibitory concentration: > 20000 nM
Compound 4: a limit, no number (the forecaster's own chance of this, stated with the estimate: 80%); the middle value lies beyond the limit too.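

In this assay, for the compounds shown here, compound 4, like compound 3, gives only a limit, so no step between the two can be read: the limit of > 20000 nM in this assay, at which 2 of the 4 values shown sit. The compounds shown leave open whether methoxy in place of hydrogen changes the activity of this core at all.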